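Chloro on the pyridine-type ring of compound 3

The source may report more compounds than this note shows. Statements on the series, on what has been measured and on what is new or still open speak of the compounds shown alone.

Compound 3 `Cc1cc(CCC(=O)O)ccc1-c1noc(-c2ccc(OC(C)C)nc2)n1` sits at the upper limit of a functional assay on CHO cells with sphingosine 1-phosphate receptor 2 (Homo sapiens) as the target, read by GTPgammaS binding; on this read-out higher numbers stand for an effect only at larger amounts of compound and lower numbers for an effect already at smaller amounts. In this assay compound 3 gives > 10000 nM, which is a limit of the assay and not a number. The two further values of the series are of the same kind. Compound 1 `Cc1cc(C(=O)O)ccc1-c1noc(-c2ccc(C3CCCCC3)cc2)n1` gives > 10000 nM in this assay, again a limit. Compound 2 `Cc1cc(CCC(=O)O)ccc1-c1noc(-c2ccc(CC(C)C)nc2)n1` gives > 10000 nM in this assay, also a limit. For the measured compounds named here, the one single-point step that connects measured compounds, a step that the two limits leave unreadable from compound 2 to compound 3, is therefore not readable in size or direction. Across the series the only evidence is the limit of > 10000 nM in this assay, at which 3 of the 3 values shown sit, so no measured step bears on the next change, and none tells how large an effect a small substituent on this ring can have.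

Compound 4 `Cc1cc(CCC(=O)O)ccc1-c1noc(-c2cnc(OC(C)C)c(Cl)c2)n1` differs from compound 3 by chloro in place of hydrogen on an aromatic carbon. With both limits unreadable, nothing in the series points to a gain past the limit, and the default expectation is that compound 4 stays where compound 3 stands. Compound 4 is estimated at 20000 nM in this assay, within 4000 nM to 100000 nM. The expected step from compound 3 to compound 4 is a step that the limit leaves unreadable from compound 3 to compound 4, with a limit rather than a number the most likely outcome.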

Compound 4, half-maximal effective concentration: > 10000 nM
Compound 4: no number, only a limit; the forecaster's own chance of this, stated with the estimate: 80%; the middle value lies beyond the limit too.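

In this assay compound 4 gives > 10000 nM, a limit of the assay and not a number. The step between compound 3 and compound 4 therefore cannot be read in size or direction. Still open is whether chloro in place of hydrogen has any effect, and where any compound of the series would give a number: the limit of > 10000 nM in this assay, at which 4 of the 4 values shown sit.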